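The source may hold more compounds than are shown below. What is called first, only, known or untested is meant among the compounds shown, and "the series" means these compounds.

Compound 1 `COC(=O)C1=C(C)NC(C)=C(C(=O)OC)C1c1cccc(OCC(=O)N2CCCC2)c1` gives 3600 nM.
Compound 2 `COC(=O)COc1ccc(C2C(C(=O)OC)=C(C)NC(C)=C2C(=O)OC)cc1` gives 2100 nM.

In an assay on cells for inhibition of Voltage-gated L-type calcium channel (Rattus norvegicus), read by fluorescence and calcium flux, with stated times of 30 min and 2 min (on this read-out higher numbers stand for weaker inhibition and lower numbers for stronger inhibition), compound 1 carries the higher of the two numbers shown, but the gap to compound 2 lies within the scatter, so no order can be read between them. Compound 3 `COC(=O)C1=C(C)NC(C)=C(C(=O)OC)C1c1cccc(OCC(=O)N2CCOCC2)c1` differs from compound 1 in one place: morpholin-4-yl in place of pyrrolidin-1-yl on a carbonyl carbon. Among the compounds with values here, no measured pair shows this change, so no step can be borrowed from the data. Compound 3 is expected to land close to compound 1, with the step of no change at the digits printed from compound 1 to compound 3 (within the scatter) staying within the scatter. The estimate for compound 3 is 3600 nM, with a range from 1400 nM to 9500 nM.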

Compound 3, half-maximal inhibitory concentration: 9900 nM
Estimate against measurement, compound 3: 2.8-fold (0.44 log units) below; measured number outside the range, above it.
By their numbers in this assay, from the lowest: compounds 2 and 1 (each within the scatter of the next); then compound 3.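

In this assay the ring on the carbonyl carbon matters: morpholin-4-yl in place of pyrrolidin-1-yl gives a 2.8-fold higher number from compound 1 to compound 3 (0.44 log units; beyond the scatter) and so a modest loss of inhibition, beyond the scatter. This is the first pair shown that differs in one place, and it shows that this position responds to a change of ring. Nothing shown gives a reason for the step.

From the compounds shown here alone, whether piperidin-1-yl or an open-chain dimethylamino group on the same carbonyl carbon would sit nearer to pyrrolidin-1-yl or to morpholin-4-yl remains open. A single pair also cannot show whether the step would hold on another core.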